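Swapping Methoxy for Trifluoromethyl on a Sulfonamide Series

The source may report more compounds than this note shows. Statements on the series, on what has been measured and on what is new or still open speak of the compounds shown alone.

Three measured compounds share one core. Compound 1 `Cc1cc(Nc2ccc(F)cc2)nc(Nc2ccc(NS(=O)(=O)c3ccccc3OC(F)(F)F)cc2)n1` gives 23800 nM in a functional assay on MDA-MB-231 cells (Homo sapiens) for antiproliferative activity, read by MTT assay; a lower number here means a stronger inhibitor, a higher number a weaker inhibitor. Compound 2 `COc1ccc(Nc2cc(C)nc(Nc3ccc(NS(=O)(=O)c4ccccc4Cl)cc3)n2)cc1` gives 15300 nM in this assay. Compound 3 `COc1ccc(Nc2ccnc(Nc3ccc(NS(=O)(=O)c4ccc(OC)cc4)cc3)n2)cc1` gives 6870 nM in this assay, the lowest of the three numbers and so the strongest inhibitor among them, as its gaps to compound 2 and to compound 1 both lie beyond the usual scatter. Compound 4 `COc1ccc(Nc2ccnc(Nc3ccc(NS(=O)(=O)c4ccc(C(F)(F)F)cc4)cc3)n2)cc1` has not yet been measured. It differs from compound 3 in one place: trifluoromethyl in place of methoxy on an aromatic carbon. Among the compounds with values here, no pair of measured compounds differs in just this way, so no known step guides the expectation. Expected is a small step, if any, toward a weaker inhibitor: a 1.3-fold higher number from compound 3 to compound 4 (0.12 log units; within the scatter). Compound 4 is therefore estimated at 9000 nM in this assay, within a range from 3000 nM to 25000 nM.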

Compound 4, half-maximal inhibitory concentration: 27200 nM
Estimate against measurement, compound 4: 3.0-fold (0.48 log units) below, outside the stated range (above it).
By their numbers in this assay, from the lowest: compound 3; then compounds 2, 1 and 4 (each within the scatter of the next).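

In this assay, within the data shown here, trifluoromethyl in place of methoxy on this aromatic carbon, para to a large group, gives a 4.0-fold higher number from compound 3 to compound 4 (0.60 log units; beyond the scatter), the first single change that can be read. It shows that this position is not indifferent to the group it carries, and that this swap leads toward a weaker inhibitor. Nothing at hand explains why the step occurs.

As far as these compounds go, whether the loss of methoxy or the arrival of trifluoromethyl matters more remains open. An amine or a nitrile at this position would help separate the two.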